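Imidazole in Place of Pyrrolidine on a Silent Scaffold

This account rests on a few compounds, and the source may have more. Where it says the series, first, only, none or still open, it means among the compounds named here.

In a functional assay on the whole organism for antagonist activity, with Mus musculus as the target (a lower number here means that less compound is needed, a higher number that more compound is needed for the effect), compound 2 (`COC(=O)N(C)C(C)C#CCN1CCCC1`) gives no number, only a limit of > 100 mg/kg. Compound 1 (`COC(=O)N(C)CC#CCn1ccnc1`) likewise returns only a limit, > 100 mg/kg. The measurements so far therefore amount to the limit of > 100 mg/kg in this assay, at which 2 of the 2 values shown sit, and no order can be read from them.

Compound 3 (`COC(=O)N(C)C(C)C#CCn1ccnc1`) carries 1H-imidazol-1-yl in place of pyrrolidin-1-yl on a saturated chain carbon bound to a triple-bonded carbon. Within the data shown here, no step between measured compounds gives a size for this change. Compound 1 already bears 1H-imidazol-1-yl, and its result is the limit > 100 mg/kg. A move to a clearly lower dose in this assay is therefore not expected, and the estimated step is a step that the limit leaves unreadable from compound 2 to compound 3. The estimate for compound 3 is 150 mg/kg, with an expected range of 60 mg/kg to 400 mg/kg.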

Compound 3, dose for half-maximal effect: > 100 mg/kg
Compound 3: a limit, no number (the forecaster's own chance of this, stated with the estimate: 75%); the middle value lies beyond the limit too.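

Compound 3 gives only a limit, as do compound 1 and compound 2, so neither step to compound 3 can be read: the limit of > 100 mg/kg in this assay, at which 3 of the 3 values shown sit.

The compounds shown leave open whether either change shifts the dose needed in this assay, and whether any of the three has a readable value there.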